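The compounds below may be only part of what the source reports. "The series", "measured", "known", "first", "only" and "open" are said of these compounds alone.

Working notes on the series. In a functional assay on HepG2 cells (Homo sapiens) for antiproliferative activity, read by MTT assay, with a stated time of 72 h (a higher number here means a weaker inhibitor of growth, a lower number a stronger inhibitor of growth), compound 1 `CC(=O)Nc1cc(OCC(C)C)nc(SCc2ccccc2)n1` gives 64400 nM and compound 2 `CC(=O)Nc1cc(OCc2ccccc2)nc(SCc2ccccc2)n1` gives 42900 nM. Compound 3 `Cc1ccc2nc(-c3ccc([N+](=O)[O-])cc3)cn2c1` gives > 100000 nM in this assay, which is a limit of the assay and not a number. Compound 4 `Cc1ccc2nc(-c3ccc(NCc4ccccc4)cc3)cn2c1` has benzylamino in place of nitro on an aromatic carbon, para to a large group: benzylamino in place of nitro on an aromatic carbon.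

Among the measured compounds shown here, only one measured step offers any guide: a 1.5-fold lower number from compound 1 to compound 2 (0.18 log units; within the scatter). It places phenyl in place of isopropyl on a saturated chain carbon bound to an oxygen on an aromatic ring, and it lies within the scatter. That step sits on a different core and at a different place, so it bears only weakly on this change. For the measured compounds named here, no step has been measured on the core of compound 3, and a limit gives no firm starting point. The data therefore give no support for a large change in this assay, and only a modest move toward a lower number is expected, with a real chance that the reading stays at the limit. The estimated step is an at least 1.6-fold lower number from compound 3 to compound 4 (0.22 log units; that floor lies within the scatter). For compound 4 the estimated value is 60000 nM, with an expected range of 20000 nM to 100000 nM.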

Compound 4, concentration for 50% growth inhibition: > 100000 nM
Compound 4: a limit, no number; the forecaster's own chance of this, stated with the estimate: 40%; at least 1.6-fold (0.22 log units) between middle value and limit.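

In this assay compound 4 gives > 100000 nM, which is a limit of the assay and not a number. No step can be read from compound 3 to compound 4 because both stand at that limit: the limit of > 100000 nM in this assay, at which 2 of the 4 values shown sit. The compounds shown leave open whether benzylamino in place of nitro on an aromatic carbon changes growth inhibition on the core of compound 3 in this assay.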